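A few compounds are considered here, and "the series" means these few. Any claim that something is new, unique, unknown or untested is made for them only; others in the source may bear on it.

Four compounds share a six-membered non-aromatic ring with two nitrogens, one carrying an acetyl group and the other a fluorophenylsulfonyl group, and differ in the group on a saturated ring carbon and in how the pieces are joined. Compound 1 is `CCOC(=O)C1CN(C(C)=O)CCN1S(=O)(=O)c1ccc(F)cc1` and compound 2 is `CCOC(=O)C1CN(S(=O)(=O)c2ccc(F)cc2)CCN1C(C)=O`; they are built from the same atoms joined differently, and the difference between the two cores is not broken down here. Compound 3 is `CC(=O)N1CCN(S(=O)(=O)c2ccc(F)cc2)C(CO)C1` and compound 4, not yet measured, is `CC(=O)N1CCN(S(=O)(=O)c2ccc(F)cc2)CC1CO`.

In a functional assay on the whole organism (strain CD-1) with Mus musculus as the target, with a stated time of 20 min (a higher number here means that more compound is needed for the effect, a lower number that less compound is needed), compound 1 gives 0.1 mg/kg, compound 2 gives 1 mg/kg and compound 3 gives 1 mg/kg. The numbers for compound 2 and compound 3 agree at the digits reported.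

Going from compound 1 to compound 3, the change is hydroxymethyl in place of ethoxycarbonyl on a saturated ring carbon. This brought a 10-fold higher number from compound 1 to compound 3 (1.00 log units; beyond the scatter). Going from compound 2 to compound 4, the change is hydroxymethyl in place of ethoxycarbonyl on a saturated ring carbon. It is the same kind of change: what leaves and what enters are identical, but the surroundings differ, since in compound 4 the carbon is next to the ring atom that bears an acetyl group and two ring bonds from the ring atom that bears a large group, whereas in compound 3 it is next to the ring atom that bears a large group and two ring bonds from the ring atom that bears an acetyl group.

If the change behaves as it did from compound 1 to compound 3, compound 4 is expected to need more compound than compound 2, with an estimated step of a 3.0-fold higher number from compound 2 to compound 4 (0.48 log units; beyond the scatter). For the measured compounds named here, only one example of this change is available. The step of a 10-fold higher number from compound 1 to compound 3 (1.00 log units; beyond the scatter) is modest, and the range is kept wide. Compound 4 is estimated at 3 mg/kg, between 1 mg/kg and 10 mg/kg.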

Compound 4, minimum effective dose in the Mus musculus assay: 10 mg/kg
Compound 4: middle estimate off by 3.3-fold (0.52 log units), on the low side, and the stated range covers the measured number.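

In the Mus musculus assay, placing hydroxymethyl where ethoxycarbonyl stood gives a 10-fold higher number from compound 2 to compound 4 (1.00 log units; beyond the scatter). Set beside the earlier step, the same change carries over from one core to the other with no readable difference in size: the same change on two cores in the Mus musculus assay, a 10-fold higher number (1.00 log units; beyond the scatter) from compound 1 to compound 3 and a 10-fold higher number (1.00 log units; beyond the scatter) from compound 2 to compound 4, 1.0-fold (0.00 log units) apart, within the scatter of two such steps This rests on just two pairs, so it shows agreement between these two cores only and does not show that the change would behave alike on any other core, nor why more compound is needed after it.

In a physicochemical assay for metabolic stability, read by LC-MS, in phosphate buffer, tested at 1 uM (a lower number here means that the compound disappears faster, a higher number that the compound lasts longer), compound 2 gives >= 4 h, which is a limit of the assay and not a number. In the physicochemical assay, compound 4 gives >= 4 h, which is also a limit. The step between the two cannot be read, so this measurement says nothing about the size of any effect of the change: the limit of >= 4 h in the physicochemical assay, at which 2 of the 2 values shown sit.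

As far as these compounds go, only ethoxycarbonyl and hydroxymethyl appear at this ring carbon, so how a carboxylic acid, an amine or a longer chain would behave there remains open. From the compounds shown here alone, it also remains open whether the close match between the two steps would hold for such groups.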